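Methanesulfonamido placement on the benzyl aromatic ring

The compounds below may be only part of what the source reports. "The series", "measured", "known", "first", "only" and "open" are said of these compounds alone.

Measured in a functional assay on H4 cells for agonist activity at growth hormone secretagogue receptor type 1 (Homo sapiens), read by FLIPR; on this read-out higher numbers stand for an effect only at larger amounts of compound and lower numbers for an effect already at smaller amounts: compound 1 `CC(C)(N)C(=O)N[C@H](COCc1ccccc1)c1nnn(Cc2ccccc2)n1` gives 1120 nM; compound 2 `CC(C)(N)C(=O)N[C@H](COCc1ccccc1)c1nnn(Cc2ccc(NS(C)(=O)=O)cc2)n1` gives 986 nM; compound 3 `CC(C)(N)C(=O)N[C@H](COCc1ccccc1)c1nnn(Cc2cccc(NS(C)(=O)=O)c2)n1` gives 868 nM.

Compound 3 shows the lowest of the three numbers, but both steps that end at it, a 1.1-fold lower number from compound 2 to compound 3 (0.06 log units; within the scatter) and a 1.3-fold lower number from compound 1 to compound 3 (0.11 log units; within the scatter), stay inside the scatter, so the three are indistinguishable. Compound 4 `CC(C)(N)C(=O)N[C@H](COCc1ccccc1)c1nnn(Cc2ccccc2NS(C)(=O)=O)n1` differs from compound 3 by 2-(methanesulfonamido)phenyl in place of 3-(methanesulfonamido)phenyl on a saturated chain carbon bound to an aromatic nitrogen. For the measured compounds named here, the steps that bear on this change are the two additions of the group, a 1.1-fold lower number from compound 1 to compound 2 (0.06 log units; within the scatter) and a 1.3-fold lower number from compound 1 to compound 3 (0.11 log units; within the scatter), and the shift of the group on the ring, a 1.1-fold lower number from compound 2 to compound 3 (0.06 log units; within the scatter), none beyond the scatter. For compound 4 no step beyond the scatter is expected, a 1.1-fold higher number from compound 3 to compound 4 (0.04 log units; within the scatter). Compound 4 is therefore estimated at 950 nM, with a range from 400 nM to 2300 nM.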

Compound 4, half-maximal effective concentration: 426 nM
Beside the measured number, compound 4's estimate is 2.2-fold (0.35 log units) above it; low and high end bracket the measured number.
By their numbers in this assay, from the lowest: compound 4; then compounds 3, 2 and 1 (each within the scatter of the next).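

In this assay, where the methanesulfonamido group sits on the ring now matters: 2-(methanesulfonamido)phenyl separates from both other placements, with a 2.0-fold lower number from compound 3 to compound 4 (0.31 log units; beyond the scatter) and a 2.3-fold lower number from compound 2 to compound 4 (0.36 log units; beyond the scatter). Only this placement also separates from the compound without the group, with a 2.6-fold lower number from compound 1 to compound 4 (0.42 log units; beyond the scatter), so adding the group is not neutral at every placement. Nothing at hand explains this difference.

Open, as far as these compounds go, is whether an amine or a carboxylic acid, in place of methanesulfonamido as held in compound 4, would keep the lower number. Also open, from the compounds shown here alone, is how a longer chain between the ring and the aromatic nitrogen would read.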